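This account rests on a few compounds, and the source may have more. Where it says the series, first, only, none or still open, it means among the compounds named here.

Working notes on one shared core. In a functional assay on HT-29 cells (Homo sapiens) for inhibition, read by MTT assay, with a stated time of 72 h (a higher number here means a weaker inhibitor, a lower number a stronger inhibitor), compound 1 `CCCNC(=C\C(=O)/C=C/c1ccc(O)c(OC)c1)/C=C/c1ccc(O)c(OC)c1` gives 22700 nM. Compound 3 `CC(=O)Oc1ccc(/C=C/C(=O)/C=C(/C=C/c2ccc(OC(C)=O)cc2)NCC(C)C)cc1` gives 13700 nM in this assay, and these two numbers lie within the scatter of each other. Compound 2 `COc1cc(/C=C/C(=O)/C=C(/C=C/c2ccc(OC(C)=O)c(OC)c2)NCC(C)C)ccc1OC(C)=O` returns only a limit in this assay, > 25000 nM, so no number stands for it (the limit of > 25000 nM in this assay, at which 1 of the 3 values shown sits). Compound 4 `COc1cc(/C=C/C(=O)/C=C(/C=C/c2ccc(O)c(OC)c2)NCC(C)C)ccc1O` has not yet been measured in this assay. Against compound 1 it shows one change, (methyl in place of hydrogen on a saturated chain carbon bound to two saturated chain carbons). Within the data shown here, no measured pair here isolates that change, so the move from compound 1 to compound 4 is expected to stay within the scatter, with no clear direction. Compound 4 is expected to give about 20000 nM in this assay, between 8000 nM and 50000 nM. The expected step is a 1.1-fold lower number from compound 1 to compound 4 (0.05 log units; within the scatter).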

Compound 4, half-maximal inhibitory concentration: 24500 nM
Estimate against measurement, compound 4: 1.2-fold (0.09 log units) below; low and high end bracket the measured number.
By their numbers in this assay, from the lowest: compounds 3, 1 and 4 (each within the scatter of the next). At a limit, above all of these: compound 2.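

Among these compounds, this is the first pair that isolates the change from propylamino to isobutylamino, and it gives a 1.1-fold higher number from compound 1 to compound 4 (0.03 log units; within the scatter) in this assay on the shared core. The added methyl leaves the read-out where it was, so this position accepts the branch with no readable change. Still open, from the compounds shown here alone, is whether a longer chain such as hexyl, or a carboxylic acid on this chain, would move the number beyond the scatter. Compound 2 carries the same isobutylamino chain but stands only at a limit, so no step to it can be read: the limit of > 25000 nM in this assay, at which 1 of the 4 values shown sits.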